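From 4-methoxyphenyl to 3-hydroxyphenyl

A few compounds are considered here, and "the series" means these few. Any claim that something is new, unique, unknown or untested is made for them only; others in the source may bear on it.

Measured in a functional assay on HT-29 cells (Homo sapiens) for antiproliferative activity, read by MTT assay, with a stated time of 48 h; a lower number here means a stronger inhibitor of growth, a higher number a weaker inhibitor of growth:
compound 1 `CCOC(=O)N1N=C(c2cccc(OC)c2)CC1c1cc(OC)c(OC)c(OC)c1` gives 7860 nM
compound 2 `COC(=O)N1N=C(c2ccc(OC)cc2)CC1c1cc(OC)c(OC)c(OC)c1` gives 2550 nM
compound 3 `CCOC(=O)N1N=C(c2ccc(OC)cc2)CC1c1cc(OC)c(OC)c(OC)c1` gives 6730 nM

In this assay compound 3, at 6730 nM, lies within the scatter of compound 1 and is separated from compound 2 by a step beyond the scatter, a 2.6-fold higher number from compound 2 to compound 3 (0.42 log units; beyond the scatter). Compound 4 `CCOC(=O)N1N=C(c2cccc(O)c2)CC1c1cc(OC)c(OC)c(OC)c1` carries 3-hydroxyphenyl in place of 4-methoxyphenyl on a carbon with a double bond to nitrogen.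

The closest measured step is a 1.2-fold lower number from compound 1 to compound 3 (0.07 log units; within the scatter), which exchanges 3-methoxyphenyl for 4-methoxyphenyl at this same place and offers no sign of a real difference. The modest step of a 2.6-fold higher number from compound 2 to compound 3 (0.42 log units; beyond the scatter) concerns the ester chain, not this place, and so offers little guidance. For the measured compounds named here, no measured compound carries a 3-hydroxyphenyl group, so that part of the change remains untested. No step beyond the scatter is therefore expected in this assay, and the estimated change is a 1.0-fold lower number from compound 3 to compound 4 (0.02 log units; within the scatter). For compound 4 the expected value is 6500 nM, with an estimated range from 2200 nM to 19000 nM.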

Compound 4, concentration for 50% growth inhibition: 11600 nM
The estimate for compound 4 lay 1.8-fold (0.25 log units) below the measured number, within the range that was stated.
By their numbers in this assay, from the lowest: compound 2; then compounds 3, 1 and 4 (each within the scatter of the next).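

In this assay, replacing 4-methoxyphenyl with 3-hydroxyphenyl gives a step that stays within the scatter (a 1.7-fold higher number from compound 3 to compound 4 (0.24 log units; within the scatter)), and the direct removal of the methyl from the oxygen on the aromatic ring does the same (a 1.5-fold higher number from compound 1 to compound 4 (0.17 log units; within the scatter)). For the compounds shown here, on the carbon with a double bond to nitrogen, a phenyl group carrying a hydrogen-bond donor therefore reads alike with both methoxyphenyl compounds, which the earlier compounds, all without such a donor, could not show. No measurement accompanying these compounds offers an explanation for this result.

The compounds shown leave open whether 4-hydroxyphenyl, or a phenyl group bearing an amine or a carboxylic acid, would read the same at this place. They also leave open whether 3-hydroxyphenyl would behave in the same way alongside the methyl ester of compound 2.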